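Benzamide in Place of the Urea on Compound 2

This account rests on a few compounds, and the source may have more. Where it says the series, first, only, none or still open, it means among the compounds named here.

Among the compounds with values here, compound 2 `COc1cc(-c2nn(-c3cccc(NC(=O)Nc4cccc(C(F)(F)F)c4)c3)cc2-c2ccncc2)ccc1Cl` is the only compound with a number in a functional assay on MCF7 cells (Homo sapiens) for inhibition, read by sulforhodamine B assay, with a stated time of 48 h (on this read-out higher numbers stand for weaker inhibition of growth and lower numbers for stronger inhibition of growth), where compound 2 gives 7720 nM. Compound 1 `O=C(Nc1cccc(-n2cc(-c3ccncc3)c(-c3ccc(Cl)c(O)c3)n2)c1)Nc1cccc(C(F)(F)F)c1` returns only a limit in this assay, > 32500 nM. Within the data shown here, the single measured step, an at least 4.2-fold lower number from compound 1 to compound 2 (0.62 log units; beyond the scatter), concerns the substituent on the ring oxygen and not the amide end of the molecule. Compound 3 `COc1cc(-c2nn(-c3cccc(NC(=O)c4ccccc4)c3)cc2-c2ccncc2)ccc1Cl` differs from compound 2 by phenyl in place of (3-(trifluoromethyl)phenyl)amino on a carbonyl carbon. Among the measured compounds shown here, no measured step bears on this change, so its size is uncertain. Compound 3 is expected to give 20000 nM, within 6000 nM to 60000 nM. That estimate means an expected 2.6-fold higher number from compound 2 to compound 3 (0.41 log units; beyond the scatter).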

Compound 3, concentration for total growth inhibition: > 100000 nM
Compound 3 gave a limit, no number; the forecaster's own chance of this, stated with the estimate: 40%; middle value at least 5.0-fold (0.69 log units) away from the limit.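

Until now only the substituent on the ring oxygen had been probed; this result shows that the group on the carbonyl carbon also matters in this assay. Phenyl in place of (3-(trifluoromethyl)phenyl)amino gives an at least 12-fold higher number from compound 2 to compound 3 (1.11 log units; beyond the scatter), a large loss of growth inhibition. Compound 3 gives only a limit and no number: the limit of > 100000 nM in this assay, at which 1 of the 3 values shown sits.

The change removes the amino nitrogen and the trifluoromethyl group together, so the compounds shown cannot tell which of them accounts for the step. Plain phenylamino on the carbonyl carbon would be one group that separates the two.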